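Adding a Methyl to the Sulfonamide: Expected Cytotoxicity

This account rests on a few compounds, and the source may have more. Where it says the series, first, only, none or still open, it means among the compounds named here.

Compound 1 `COc1cc(NC(=O)c2ccc(C#N)cc2)ccc1NS(C)(=O)=O` in an ADME assay on HEK293 cells (Homo sapiens) for cytotoxicity, read by MTT assay, with a stated time of 48 h (on this read-out higher numbers stand for weaker inhibition and lower numbers for stronger inhibition), gives > 250000 nM, which is a limit of the assay and not a number.
Compound 2 `CCS(=O)(=O)Nc1ccc(NC(=O)c2ccc(C#N)cc2)cc1OC` in this assay gives > 250000 nM, likewise a limit and not a number.
Among the compounds with values here, compound 3 `CS(=O)(=O)Nc1ccc(NC(=O)c2ccc(Cl)cc2)cc1Cl` in this assay gives 167000 nM, the only number among the three.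

The change from compound 1 to compound 2 is methyl in place of hydrogen on a saturated chain carbon bound to a sulfonyl sulfur. Its step, a step that the two limits leave unreadable from compound 1 to compound 2, cannot be sized because of the limit of > 250000 nM in this assay, at which 2 of the 3 values shown sit. Compound 4 `CCS(=O)(=O)Nc1ccc(NC(=O)c2ccc(Cl)cc2)cc1Cl` is not yet measured; it carries the same change on the core of compound 3, (methyl in place of hydrogen on a saturated chain carbon bound to a sulfonyl sulfur), at the same place. How the core of compound 3 differs from the core of compound 1 is not broken down here. Resting on a step that the two limits leave unreadable from compound 1 to compound 2, which offers no readable size, the expected step for compound 4 is a 1.1-fold higher number from compound 3 to compound 4 (0.03 log units; within the scatter). In this assay compound 4 is estimated at 180000 nM, with a likely range from 80000 nM to 250000 nM.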

Compound 4, half-maximal inhibitory concentration: > 250000 nM
Compound 4 gave a limit, no number (the forecaster's own chance of this, stated with the estimate: 40%); middle value at least 1.3-fold (0.14 log units) from the limit.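

In this assay, the change from methylsulfonyl to ethylsulfonyl on the core of compound 3 gives an at least 1.4-fold higher number from compound 3 to compound 4 (0.17 log units; that floor lies within the scatter), and this floor alone does not establish a real change, although the true step may be larger. The same change on the core of compound 1 cannot be read, so these results neither confirm nor rule out that it carries over from one core to the other with a similar size. The comparison stays open because neither step has a measured upper end: the limit of > 250000 nM in this assay, at which 3 of the 4 values shown sit.

The compounds shown leave open how a longer chain, such as propylsulfonyl in place of ethylsulfonyl, would read in this assay. They also leave open whether an amine on that chain would give a number rather than a limit on either core.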